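Swapping the amine substituent on a sulfamate series

A few compounds are considered here, and "the series" means these few. Any claim that something is new, unique, unknown or untested is made for them only; others in the source may bear on it.

Of the compounds shown here, two share one core and have been measured in an assay on HEK293 cells for inhibition of Steryl-sulfatase (Homo sapiens), tested at 1 uM; on this read-out lower numbers stand for a weaker effect and higher numbers for a stronger effect at the one concentration tested. Compound 1, `NS(=O)(=O)Oc1ccc2c(c1)CN(C(=O)c1ccc(N(Cc3ccccc3)Cc3ccco3)cc1)CC2`, gives 98.2% in this assay. Compound 2, `CCN(Cc1ccc(F)cc1)c1ccc(C(=O)N2CCc3ccc(OS(N)(=O)=O)cc3C2)cc1`, gives 91.2% in this assay; its number stands alongside that of compound 1, the two lying within the usual scatter of each other, so the data show no distinction between them.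

Compound 3, `CCCN(Cc1ccccc1)c1ccc(C(=O)N2CCc3ccc(OS(N)(=O)=O)cc3C2)cc1`, has not yet been measured in this assay. Its structure differs from that of compound 2 in one place: benzyl(propyl)amino in place of ethyl(4-fluorobenzyl)amino on an aromatic carbon. Both the group that leaves and the group that enters carry one six-membered aromatic ring of carbon only and one hydrogen-bond acceptor, with no donor and no net charge.

For the measured compounds named here, no step between measured compounds is available to set the size of this change. With compound 1 and compound 2 both reading high in this assay, the step from compound 2 to compound 3 is expected to be small, a number 1.8 percentage points higher from compound 2 to compound 3 (within the scatter), with no change beyond the scatter in either direction. Compound 3 is therefore expected to read about 93% in this assay, within a range from 84% to 99%.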

Compound 3, a percentage reported as inhibition, at one concentration (the size of the read-out at that concentration, not a potency): 94.3%
Compound 3: the middle estimate sits 1.3 percentage points below what was measured; the measured number falls inside the stated range.
By their numbers in this assay, from the lowest: compounds 2, 3 and 1 (each within the scatter of the next).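

Two single-place changes now exist in this series, and neither moves the read-out beyond the usual scatter. In this assay, benzyl(propyl)amino in place of ethyl(4-fluorobenzyl)amino on this aromatic carbon, para to a large group, gives a number 3.1 percentage points higher from compound 2 to compound 3 (within the scatter), so the read-out does not separate the two substituents, even though the fluorine is lost and the chain differs. Ethyl in place of furan-2-yl on the saturated chain carbon bound to a nitrogen on an aromatic ring gives a number 3.9 percentage points lower from compound 1 to compound 3 (within the scatter), so in this pair the furan-2-yl ring is not needed for a high reading, and nothing measured here explains this tolerance.

On these data alone, all three compounds read high at a single concentration, so whether their potencies differ remains open, as a full concentration series could show differences that this read-out does not. As far as these compounds go, it is also open whether the reading would hold with a carboxylic acid or a primary amine on the benzyl ring, or with a plain dimethylamino group in place of the whole substituent.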